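A few compounds are considered here, and "the series" means these few. Any claim that something is new, unique, unknown or untested is made for them only; others in the source may bear on it.

Compound 1 `COc1cccc(OC)c1C(=O)Nc1c[nH]nc1C(=O)NC1CCC1` carries the shared core with a cyclobutylamino group on one carbonyl carbon and a dimethoxyphenyl group on the other. In an ADME assay on MRC5 cells (Homo sapiens) for inhibition, with a stated time of 72 h (on this read-out lower numbers stand for an effect already at smaller amounts and higher numbers for an effect only at larger amounts of compound), compound 1 returns only a limit of the assay, > 50000 nM. Two further compounds share the core but bear a different amine. Compound 2 `CO[C@H]1CC[C@H](NC(=O)c2n[nH]cc2NC(=O)c2cnc3ccccn23)CC1` gives 5900 nM in this assay, and compound 3 `CO[C@H]1CC[C@H](NC(=O)c2n[nH]cc2NC(=O)c2ccccc2F)CC1` gives 1000 nM. Going by the values given here, the single step measured between close neighbours is a 5.9-fold lower number from compound 2 to compound 3 (0.77 log units; beyond the scatter), a change of the acyl group on a carbonyl carbon, and it is the only step of its kind here.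

Compound 4 `COC(=O)c1n[nH]cc1NC(=O)c1c(OC)cccc1OC` is the unmeasured partner of compound 1 and differs from it at the other carbonyl: methoxy in place of cyclobutylamino on a carbonyl carbon. Among the compounds with values here, no measured step touches this position, so the step from compound 2 to compound 3 offers no guidance on the direction or size of the change from compound 1 to compound 4. What is known is that compound 1 sits at the limit (the limit of > 50000 nM in this assay, at which 1 of the 3 values shown sits). Compound 4 is therefore expected to stay close to that limit, with an estimate of 50000 nM in this assay and a range from 15000 nM to 150000 nM. The expected step is a number no higher from compound 1 to compound 4 (the limit leaves the size open), not beyond the scatter.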

Compound 4, half-maximal effective concentration: > 50000 nM
Compound 4: no number, only a limit; the forecaster's own chance of this, stated with the estimate: 70%; the middle value sits exactly at the limit.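

Compound 1 and compound 4 both return only a limit in this assay, so no step can be read for methoxy in place of cyclobutylamino on a carbonyl carbon. The compounds shown leave open whether this change alters the read-out at all, and how far either compound lies from the limit: the limit of > 50000 nM in this assay, at which 2 of the 4 values shown sit.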